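Swapping the aryl group on the amine of compound 3

The compounds below may be only part of what the source reports. "The series", "measured", "known", "first", "only" and "open" are said of these compounds alone.

Of the compounds shown here, three sharing one core have been measured in an assay on isolated protein for inhibition of Dihydrofolate reductase (Homo sapiens), read by spectrophotometry; a lower number here means a stronger inhibitor, a higher number a weaker inhibitor. Compound 1 `CN(Cc1nc2cc(C(F)(F)F)ccc2nc1-c1ccccc1)c1ccc(Cl)cc1` gives 5000 nM. Compound 2 `Cc1ccc(N(C)Cc2nc3cc(C(F)(F)F)ccc3nc2-c2ccccc2)cc1` gives 11000 nM. Compound 3 `CCN(Cc1nc2cc(C(F)(F)F)ccc2nc1-c1ccccc1)c1ccc(F)cc1` gives 3000 nM, the lowest of the three numbers. The step of a 1.7-fold lower number from compound 1 to compound 3 (0.22 log units; within the scatter) lies within the scatter, whereas a 3.7-fold lower number from compound 2 to compound 3 (0.56 log units; beyond the scatter) and a 2.2-fold higher number from compound 1 to compound 2 (0.34 log units; beyond the scatter) lie beyond it.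

Compound 4 `CCN(Cc1nc2cc(C(F)(F)F)ccc2nc1-c1ccccc1)c1cc(OC)c(OC)c(OC)c1` carries 3,4,5-trimethoxyphenyl in place of 4-fluorophenyl on an amine nitrogen. The three measured steps all changed the substituted amino group, and each was at most modest in size. Among the compounds with values here, no measured compound carries a trimethoxyphenyl group, so the direction is open. A modest step in this assay is therefore expected, a 1.5-fold lower number from compound 3 to compound 4 (0.18 log units; within the scatter). Compound 4 is expected to give about 2000 nM, in a range from 500 nM to 8000 nM.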

Compound 4, inhibition constant: 6000 nM
Beside the measured number, compound 4's estimate is 3.0-fold (0.48 log units) below it; low and high end bracket the measured number.
By their numbers in this assay, from the lowest: compounds 3, 1, 4 and 2 (each within the scatter of the next, the first and the last beyond it).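

Replacing 4-fluorophenyl, with 7 heavy atoms and no hydrogen-bond acceptors, by 3,4,5-trimethoxyphenyl, with 12 heavy atoms and 3 hydrogen-bond acceptors, gives a 2.0-fold higher number from compound 3 to compound 4 (0.30 log units; within the scatter) in this assay. This much larger group on the amine nitrogen therefore leaves compound 4 indistinguishable from compound 3 in this assay. Nothing available here explains this result.

As far as these compounds go, it remains open whether a single methoxy group or an amine on the aromatic ring, or a propyl chain on the nitrogen in place of ethyl, would give a step beyond the scatter.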